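Replacing the Benzyl Ether by a Hexyl Chain

This account rests on a few compounds, and the source may have more. Where it says the series, first, only, none or still open, it means among the compounds named here.

Compound 1 `CN(c1ccc(NC(=O)c2ccc(C(F)(F)F)cc2C(F)(F)F)cc1OCc1cccc(C(F)(F)F)c1)S(C)(=O)=O` gives in an ADME assay on HEK293 cells (Homo sapiens) for cytotoxicity, read by MTT assay, with a stated time of 48 h (on this read-out lower numbers stand for stronger inhibition and higher numbers for weaker inhibition), the limit > 500000 nM.
Compound 2 `CN(c1ccc(NC(=O)c2ccc(C(F)(F)F)cc2C(F)(F)F)cc1OCc1ccccc1C(F)(F)F)S(C)(=O)=O` gives in this assay the limit > 500000 nM.
Compound 3 `Cc1ccc(C(F)(F)F)cc1COc1cc(NC(=O)c2ccc(C(F)(F)F)cc2C(F)(F)F)ccc1N(C)S(C)(=O)=O` gives in this assay the limit > 500000 nM.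

Compound 3 therefore stands where the other two measured compounds stand: at a limit of this assay, not at a number. The three steps among the measured compounds, a step that the two limits leave unreadable from compound 1 to compound 2, a step that the two limits leave unreadable from compound 1 to compound 3 and a step that the two limits leave unreadable from compound 2 to compound 3, cannot be read in size or direction because of the limit of > 500000 nM in this assay, at which 3 of the 3 values shown sit.

Compound 4 `CCCCCCOc1cc(NC(=O)c2ccc(C(F)(F)F)cc2C(F)(F)F)ccc1N(C)S(C)(=O)=O` differs from compound 3 in one place: pentyl in place of 2-methyl-5-(trifluoromethyl)phenyl on a saturated chain carbon bound to an oxygen on an aromatic ring. For the measured compounds named here, none of the measured steps speaks to this exchange, and none of them is readable; the only guide is that every compound sharing the core sits at the same limit.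

On that basis compound 4 is expected to show no change beyond the scatter, an estimated step of a number no higher from compound 3 to compound 4 (the limit leaves the size open). The estimate for compound 4 in this assay is 500000 nM, within a range from 150000 nM to 1000000 nM, most likely again reported only as a limit.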

Compound 4, half-maximal inhibitory concentration: > 500000 nM
Compound 4 gave a limit, no number; the forecaster's own chance of this, stated with the estimate: 80%; the middle value sits exactly at the limit.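

In this assay compound 4 gives > 500000 nM, a limit and not a number. No step from compound 1, compound 2 or compound 3 to compound 4 can be read, because the values coincide at one boundary: the limit of > 500000 nM in this assay, at which 4 of the 4 values shown sit.

The compounds shown leave open whether hexyl and the substituted benzyl groups differ at all in this read-out.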